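A few compounds are considered here, and "the series" means these few. Any claim that something is new, unique, unknown or untested is made for them only; others in the source may bear on it.

Measured compounds:
compound 1 `C=CC(=O)Nc1cccc(Nc2nc(Cl)nc(Nc3ccc(OCCOC)cc3)n2)c1` — "not determined" (no result reported)
compound 2 `C=CC(=O)Nc1cccc(Nc2ncnc(Nc3ccc(OC)cc3)n2)c1` — 90000 nM
compound 3 `C=CC(=O)Nc1cccc(Nc2ncnc(Nc3ccc(-c4ccc(C)nc4)cc3)n2)c1` — "not determined" (no result reported)

Compound 3 stands without a number in a functional assay on Ramos cells (Homo sapiens) for antiproliferative activity, read by CCK-8 assay, with a stated time of 24 h (a lower number here means a stronger inhibitor, a higher number a weaker inhibitor), giving "not determined" (no result reported); compound 1 is likewise without one, giving "not determined" (no result reported), so the only anchor in this assay is compound 2, which gives 90000 nM. Compound 4 `C=CC(=O)Nc1cccc(Nc2ncnc(Nc3ccc(OCCOC)cc3)n2)c1` is the next member, differing from compound 3 by 2-methoxyethoxy in place of 6-methylpyridin-3-yl on an aromatic carbon. Among the compounds with values here, with no measured step between any two compounds, the size and direction of this change cannot be read from the data. The expectation for compound 4 rests on compound 2, whose value of 90000 nM places the shared core at weak potency. Compound 4 is therefore expected near 60000 nM, with an estimated range from 10000 nM to 200000 nM.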

Compound 4, half-maximal inhibitory concentration: 181000 nM
The estimate for compound 4 lay 3.0-fold (0.48 log units) below the measured number, and the stated range covers the measured number.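

In this assay, within the data shown here, methoxymethyl in place of hydrogen on the saturated chain carbon bound to an oxygen on an aromatic ring gives a 2.0-fold higher number from compound 2 to compound 4 (0.30 log units; within the scatter) and provides the first readable step. At this position, the methoxy of compound 2 and the 2-methoxyethoxy of compound 4 cannot be told apart. No evidence on hand explains this result.
The steps from compound 1 and compound 3 to compound 4 cannot be read, as neither compound has a number. Also open, from the compounds shown here alone, is whether an amine, a carboxylic acid or a longer chain at this position would give a step beyond the scatter.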